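Removing a methyl branch from a carboxylic acid chain

The source may report more compounds than this note shows. Statements on the series, on what has been measured and on what is new or still open speak of the compounds shown alone.

Compound 1 `CC(CCc1ccc(OCc2ccc3ccccc3n2)cc1)Cc1nnn[nH]1` gives 25 nM in an assay on membranes from lung (Cavia porcellus) for binding affinity to cysteinyl leukotriene receptor (Homo sapiens); on this read-out higher numbers stand for weaker inhibition and lower numbers for stronger inhibition.
Compound 2 `O=C(O)CCCOc1ccc(OCc2ccc3ccccc3n2)cc1` gives 1200 nM in this assay.
Compound 3 `CC(CCC(=O)O)Cc1ccc(OCc2ccc3ccccc3n2)cc1` gives 43 nM in this assay.

Among these three numbers, compound 3 stands second highest. Nearest is compound 1: the step of a 1.7-fold higher number from compound 1 to compound 3 (0.24 log units; within the scatter) lies within the scatter, so the two cannot be told apart. Furthest is compound 2: the step of a 28-fold lower number from compound 2 to compound 3 (1.45 log units; beyond the scatter) is large and beyond the scatter.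

Compound 4 `O=C(O)CCCCc1ccc(OCc2ccc3ccccc3n2)cc1` is not yet measured. It differs from compound 3 in one place: hydrogen in place of methyl on a saturated chain carbon bound to two saturated chain carbons. Put otherwise, 3-carboxy-1-methylpropyl becomes 3-carboxypropyl.

For the measured compounds named here, no measured step removes a methyl on its own. The step from compound 2 to compound 3 turns 3-carboxypropoxy into 4-carboxy-2-methylbutyl, so the methyl arrives together with a different chain and its own share cannot be separated. The step from compound 1 to compound 3 concerns the acid group and says nothing about the methyl. The expectation therefore rests on compound 3 alone at 43 nM, and the step in this assay is expected to be small, probably toward a somewhat higher number, with wide uncertainty. Compound 4 is expected at 100 nM, between 30 nM and 350 nM. The estimated step is a 2.3-fold higher number from compound 3 to compound 4 (0.37 log units; beyond the scatter).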

Compound 4, inhibition constant: 110 nM
For compound 4 the middle estimate is 1.1-fold (0.04 log units) below the measured one, and the stated range covers the measured number.
By their numbers in this assay, from the lowest: compounds 1 and 3 (each within the scatter of the next); then compound 4; then compound 2.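

In this assay, the methyl now has a share of its own: taking it away, with nothing else changed, gives a 2.6-fold higher number from compound 3 to compound 4 (0.41 log units; beyond the scatter), a modest step, so the branch on this saturated chain carbon does count. The unbranched chain still keeps a large lead over the ether-linked one, with an 11-fold lower number from compound 2 to compound 4 (1.04 log units; beyond the scatter), which means that most of the gap seen with the branched chain remains once the methyl is gone. The unbranched acid can also be set against the tetrazole compound, with a 4.4-fold higher number from compound 1 to compound 4 (0.64 log units; beyond the scatter), although this step changes the acid group and removes the methyl at once, so it does not separate the two, and compound 1 and compound 3 could not be told apart.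

Nothing available here explains why losing the methyl moves the number. From the compounds shown here alone, it also remains open how an ethyl group on the same saturated chain carbon, or a longer chain ending in the carboxylic acid, would read in this assay, and so whether the methyl is the best choice at this position.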